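A second chlorine on the urea of compound 2

The source may hold more compounds than are shown below. What is called first, only, known or untested is meant among the compounds shown, and "the series" means these compounds.

Measured so far:
compound 1, `O=C(Nc1cc(Cl)nc(Cl)c1)Nc1cc2ccc(-c3ccccc3)cn2n1`: 8050 nM
compound 2, `O=C(Nc1ccnc(Cl)c1)Nc1cc(Cl)nc(Cl)c1`: 55300 nM

In an ADME assay on NCM460 cells (Homo sapiens) for cytotoxicity, read by MTT assay, with a stated time of 72 h, in the presence of a further agent that is not named here (a higher number here means that more compound is needed for the effect, a lower number that less compound is needed), compound 2 gives the highest of the two numbers; compound 1 gives a lower number, and the gap between the two lies beyond the scatter. Compound 3, `O=C(Nc1cc(Cl)nc(Cl)c1)Nc1cc(Cl)nc(Cl)c1`, differs from compound 2 by chloro in place of hydrogen on an aromatic carbon. For the measured compounds named here, no measured pair shows this change, so its effect is unknown. The account expects no step beyond the scatter, with the expected step being a 1.4-fold lower number from compound 2 to compound 3 (0.14 log units; within the scatter). Compound 3 is therefore estimated at 40000 nM, within a range from 15000 nM to 110000 nM.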

Compound 3, half-maximal effective concentration: 9440 nM
Compound 3: middle estimate off by 4.2-fold (0.63 log units), on the high side, and the stated range ends above it.
By their numbers in this assay, from the lowest: compounds 1 and 3 (each within the scatter of the next); then compound 2.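

In this assay, chloro in place of hydrogen on an aromatic carbon, next to the ring nitrogen, gives a 5.9-fold lower number from compound 2 to compound 3 (0.77 log units; beyond the scatter). For the compounds shown here, this is the first step measured at this position, and it shows that a change of one heavy atom there is enough to move the number beyond the scatter. Nothing available here accounts for the size of this step. As far as these compounds go, whether a methyl, a methoxy or an amine at this position would give a similar step stays open, as does whether chloro would do the same on the core of compound 1.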